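The source may report more compounds than this note shows. Statements on the series, on what has been measured and on what is new or still open speak of the compounds shown alone.

Compound 3 `O=C(CCCc1ccccc1)Nc1ccc(N2CCN(c3ccc(OC[C@@H]4CO[C@@](Cn5cncn5)(c5ccc(Cl)cc5Cl)O4)cc3)CC2)cc1` gives 10800 nM in a functional assay on HepG2 cells (Homo sapiens) for inhibition, read by MTT assay, with a stated time of 48 h; a lower number here means a stronger inhibitor, a higher number a weaker inhibitor. Its number is the lowest of the three measured, but the other two sit close by. Compound 1 `CCCCC(=O)Nc1ccc(N2CCN(c3ccc(OC[C@@H]4CO[C@@](Cn5cncn5)(c5ccc(Cl)cc5Cl)O4)cc3)CC2)cc1` gives 14100 nM, and compound 2 `O=C(CC1CCOCC1)Nc1ccc(N2CCN(c3ccc(OC[C@@H]4CO[C@@](Cn5cncn5)(c5ccc(Cl)cc5Cl)O4)cc3)CC2)cc1` gives 21100 nM. The step of a 1.3-fold lower number from compound 1 to compound 3 (0.12 log units; within the scatter) and the step of a 2.0-fold lower number from compound 2 to compound 3 (0.29 log units; within the scatter) both fall within the scatter of repeated measurements, so these three compounds cannot be told apart on the numbers in hand. All three share one core and differ only in the tail carried on the amide.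

Compound 4 `O=C(CCc1ccccc1)Nc1ccc(N2CCN(c3ccc(OC[C@@H]4CO[C@@](Cn5cncn5)(c5ccc(Cl)cc5Cl)O4)cc3)CC2)cc1` has not yet been measured. Compared with compound 3 it carries phenyl in place of benzyl on a saturated chain carbon, two bonds along the chain from a carbonyl carbon, so the aromatic ring stays but the chain between the carbonyl and the ring is shorter. The measured steps that bear on this are the earlier tail changes, a 1.3-fold lower number from compound 1 to compound 3 (0.12 log units; within the scatter) and a 2.0-fold lower number from compound 2 to compound 3 (0.29 log units; within the scatter), neither of which moved the number in this assay beyond the scatter. On that basis the expected step of a 1.1-fold higher number from compound 3 to compound 4 (0.05 log units; within the scatter) for compound 4 is a small one, with no change beyond the scatter in either direction. Compound 4 is therefore estimated at 12000 nM in this assay, within a range from 6000 nM to 25000 nM.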

Compound 4, half-maximal inhibitory concentration: 5340 nM
Compound 4: the middle estimate sits 2.2-fold (0.35 log units) above what was measured, and the stated range ends above it.
By their numbers in this assay, from the lowest: compound 4; then compounds 3, 1 and 2 (each within the scatter of the next).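

In this assay, among the compounds shown here, the amide tail now makes a difference: shortening 3-phenylpropyl to phenethyl gives a 2.0-fold lower number from compound 3 to compound 4 (0.31 log units; beyond the scatter), the first step at this position to pass the scatter, though only a modest one. The aromatic ring is present in both tails, so having that ring is not enough to set the number, and chain length matters here, at least for this pair; compared with the other tails, the steps are a 2.6-fold lower number from compound 1 to compound 4 (0.42 log units; beyond the scatter) and a 4.0-fold lower number from compound 2 to compound 4 (0.60 log units; beyond the scatter), which leaves compound 4 as the strongest inhibitor of the four in this cell assay. Nothing at hand accounts for why removing this part of the chain lowers the number.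

On these data alone, it remains open whether a still shorter tail, with benzyl or phenyl directly on the carbonyl, would lower the number further or raise it again, so the best chain length is not yet fixed. Also open, as far as these compounds go, is how the phenethyl tail would respond to a fluorine, an amine or a carboxylic acid on its ring.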